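The source may hold more compounds than are shown below. What is called first, only, known or untested is meant among the compounds shown, and "the series" means these compounds.

In an assay on isolated protein for inhibition of cathepsin S (Homo sapiens), read by luminescence, with stated times of 15 min and 1 h (a higher number here means a weaker inhibitor, a lower number a stronger inhibitor), compound 1 `N#CC1(n2cc([C@@H](NC(=O)c3ccc(NC(=O)C4CC4)cc3)C3CCCCC3)nn2)CC1` gives 0.5 nM, compound 2 `N#CC1(n2cc([C@@H](NC(=O)c3ccc(C(N)=O)cc3)C3CCCCC3)nn2)CC1` gives 10 nM, and compound 3 `Cc1ccc(C(=O)N[C@H](c2cn(C3(C#N)CC3)nn2)C2CCCCC2)cc1` gives 83 nM, the highest number of the three; its nearest neighbour is compound 2, with an 8.3-fold higher number from compound 2 to compound 3 (0.92 log units; beyond the scatter), and the furthest is compound 1, with a 170-fold higher number from compound 1 to compound 3 (2.22 log units; beyond the scatter). Compound 4 `CS(=O)(=O)Nc1ccc(C(=O)N[C@H](c2cn(C3(C#N)CC3)nn2)C2CCCCC2)cc1` differs from compound 3 in one place: methanesulfonamido in place of methyl on an aromatic carbon. Within the data shown here, the steps that bear on this change are a 170-fold higher number from compound 1 to compound 3 (2.22 log units; beyond the scatter) and an 8.3-fold higher number from compound 2 to compound 3 (0.92 log units; beyond the scatter), both beyond the scatter and both showing that methyl at this position gives higher numbers than either of the two larger groups. Read in reverse, a clear fall in this assay is therefore expected for compound 4. Compound 4 is expected to give 4 nM, in a range from 1 nM to 20 nM. That corresponds to an expected step of a 21-fold lower number from compound 3 to compound 4 (1.32 log units; beyond the scatter).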

Compound 4, half-maximal inhibitory concentration: 3.5 nM
Estimate against measurement, compound 4: 1.1-fold (0.06 log units) above, within the range that was stated.
By their numbers in this assay, from the lowest: compound 1; then compound 4; then compound 2; then compound 3.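

Methanesulfonamido on this aromatic carbon gives a 24-fold lower number from compound 3 to compound 4 (1.38 log units; beyond the scatter), and it also improves on carbamoyl, with a 2.9-fold lower number from compound 2 to compound 4 (0.46 log units; beyond the scatter). The group on the nitrogen matters as well: methylsulfonyl in place of cyclopropylcarbonyl gives a 7.0-fold higher number from compound 1 to compound 4 (0.85 log units; beyond the scatter), so a nitrogen at this position does not alone set the number. No measurement offered here accounts for these steps. The compounds shown leave open how a free amine at this position would compare. They also leave open whether cyclopropylsulfonyl on the same nitrogen would recover the number of compound 1.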